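Cytotoxicity notes on a diaryl-triazine piperazine series

The source may report more compounds than this note shows. Statements on the series, on what has been measured and on what is new or still open speak of the compounds shown alone.

Compound 1 `COc1ccccc1N1CCN(CC(=O)N2CCN(c3nnc(-c4ccccc4)c(-c4ccccc4)n3)CC2)CC1` and compound 2 `O=C(CN1CCN(c2ccccc2Cl)CC1)N1CCN(c2nnc(-c3ccccc3)c(-c3ccccc3)n2)CC1` share one core and differ in a single place: chloro in place of methoxy on an aromatic carbon. In an ADME assay on NIH3T3 cells (Mus musculus) for cytotoxicity, read by MTT assay, with a stated time of 24 h (a lower number here means a stronger inhibitor, a higher number a weaker inhibitor), compound 1 gives 444000 nM. In this assay compound 2 gives 350000 nM. The step of a 1.3-fold lower number from compound 1 to compound 2 (0.10 log units; within the scatter) is the size to keep in mind for the change below.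

Compound 3 `COc1ccc(N2CCN(CC(=O)N3CCN(c4nnc(-c5ccccc5)c(-c5ccccc5)n4)CC3)CC2)cc1` keeps the same atoms as compound 1, joined differently: 4-methoxyphenyl in place of 2-methoxyphenyl on an amine nitrogen in a ring. For compound 3 this assay reports only a limit, > 910000 nM. The steps of an at least 2.0-fold higher number from compound 1 to compound 3 (0.31 log units; beyond the scatter) and an at least 2.6-fold higher number from compound 2 to compound 3 (0.41 log units; beyond the scatter) are therefore read as at least modest, and that reading rests on (the limit of > 910000 nM in this assay, at which 1 of the 3 values shown sits).

Compound 4 `O=C(CN1CCN(c2ccc(Cl)cc2)CC1)N1CCN(c2nnc(-c3ccccc3)c(-c3ccccc3)n2)CC1` is the unmeasured member. It differs from compound 3 in the way counted here: chloro in place of methoxy on an aromatic carbon. This is the same kind of change as from compound 1 to compound 2, not the same change: around the place, the group in compound 4 sits para to a large group, where in compound 2 it sits ortho to a large group.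

The expected step is a number no higher from compound 3 to compound 4 (the limit leaves the size open), which rests on compound 1 and compound 2, whose step a 1.3-fold lower number from compound 1 to compound 2 (0.10 log units; within the scatter) lay within the scatter. Because compound 3 sits at the limit of > 910000 nM in this assay, at which 1 of the 3 values shown sits, compound 4 is also expected to fall at or near that limit. Compound 4 is estimated at 900000 nM in this assay, with an expected spread from 450000 nM to 2000000 nM.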

Compound 4, half-maximal inhibitory concentration: 113000 nM
Beside the measured number, compound 4's estimate is 8.0-fold (0.90 log units) above it; the whole stated range lies above it.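

In this assay, chloro in place of methoxy does not carry over from one core to the other as a step of one size: the same change on two cores in this assay, a 1.3-fold lower number (0.10 log units; within the scatter) from compound 1 to compound 2 and an at least 8.0-fold lower number (0.90 log units; beyond the scatter) from compound 3 to compound 4, at least 6.3-fold (0.80 log units) apart, beyond the scatter of two such steps

Compound 4 gives the lowest number of the four, with an at least 8.0-fold lower number from compound 3 to compound 4 (0.90 log units; beyond the scatter), a 3.1-fold lower number from compound 2 to compound 4 (0.49 log units; beyond the scatter) and a 3.9-fold lower number from compound 1 to compound 4 (0.59 log units; beyond the scatter), and the first of these steps is sized against a limit only: the limit of > 910000 nM in this assay, at which 1 of the 4 values shown sits.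

This does not amount to a rule, as two pairs say nothing about further cores, and the pairs also differ in where the group sits, 2-methoxyphenyl to 2-chlorophenyl in one and 4-methoxyphenyl to 4-chlorophenyl in the other, so the data give no cause for the gap between them.

The compounds shown leave open how far the 4-chlorophenyl result depends on chloro itself, as opposed to any group other than methoxy at that place, and a fluoro, a methyl or an amine there would test this. Also open, from the compounds shown here alone, is the true size of the step into compound 4, as compound 3 has no number of its own, only a limit.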